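Tetrabromo core with a diol side chain: an expectation

The compounds below may be only part of what the source reports. "The series", "measured", "known", "first", "only" and "open" are said of these compounds alone.

Two compounds share one core. Compound 1 `OC(CCn1nc2c(Br)c(Br)c(Br)c(Br)c2n1)c1cccc(Cl)c1` and compound 2 `C[C@H](O)CCn1nc2c(Br)c(Br)c(Br)c(Br)c2n1` were tested in a functional assay on CCRF-CEM cells (Homo sapiens) for antiproliferative activity, read by MTT assay, with a stated time of 24 h, tested at 25 uM; on this read-out lower numbers stand for a stronger effect and higher numbers for a weaker effect at the one concentration tested. In this assay compound 1 gives 118%, and compound 2 gives 112%; these two numbers lie within the scatter of each other, so neither can be called the stronger. Compound 3 `OCC(O)Cn1nc2c(Br)c(Br)c(Br)c(Br)c2n1` has not been measured. It differs from compound 2 by 1,2-dihydroxyethyl in place of 2-hydroxypropyl on a saturated chain carbon bound to an aromatic nitrogen. Within the data shown here, with only two measured compounds and no comparable step, the expected change from compound 2 to compound 3 is a number 2 percentage points lower from compound 2 to compound 3 (within the scatter), none beyond the scatter. Compound 3 is therefore estimated at 110%, within 90% to 130%.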

Compound 3, a percentage reported as activity, at one concentration (the size of the read-out at that concentration, not a potency): 89%
Beside the measured number, compound 3's estimate is 21 percentage points above it; the whole stated range lies above it.
By their numbers in this assay, from the lowest: compound 3; then compounds 2 and 1 (each within the scatter of the next).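

In this assay, replacing 2-hydroxypropyl with 1,2-dihydroxyethyl on this saturated chain carbon gives a number 23 percentage points lower from compound 2 to compound 3 (beyond the scatter). This shows that the number can respond to a small side-chain change with the shared core held constant: both groups have 4 heavy atoms, while the entering group has 2 hydrogen-bond donors and the leaving group has 1. Nothing available explains the shift. Still open, on these data alone, is how the read-out would respond to an amine or a carboxylic acid at this place, or to a longer chain bearing two hydroxyl groups.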